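The source may hold more compounds than are shown below. What is called first, only, known or untested is meant among the compounds shown, and "the series" means these compounds.

Working notes on the series. The three measured compounds share one core: compound 1 is `Cc1cccc(C(Nc2ccc(C)cc2Cl)C(=O)CCc2ccncc2)c1`, compound 2 is `COc1cccc(C(Nc2ccc(C)cc2Cl)C(=O)CCc2ccncc2)c1` and compound 3 is `Cc1ccc(NC(C(=O)CCc2ccncc2)c2ccc(Cl)cc2)c(Cl)c1`. In an assay on isolated protein for binding affinity to corticotropin-releasing factor receptor 1 (Homo sapiens) (a higher number here means a weaker inhibitor, a lower number a stronger inhibitor), compound 1 gives only a limit, > 10000 nM. Compound 2 likewise gives only a limit in this assay, > 10000 nM. Compound 3 also gives only a limit in this assay, > 10000 nM. Compound 3 thus stands at the limit of > 10000 nM in this assay, at which 3 of the 3 values shown sit, and nothing ranks it against compounds 1 and 2. The steps a step that the two limits leave unreadable from compound 1 to compound 2, a step that the two limits leave unreadable from compound 1 to compound 3 and a step that the two limits leave unreadable from compound 2 to compound 3 are accordingly unreadable in size.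

Compound 4 is `Cc1ccc(C(Nc2ccc(C)cc2Cl)C(=O)CCc2ccncc2)cc1`; the change is methyl in place of chloro on an aromatic carbon. For the measured compounds named here, the steps from compounds 1 and 2 to compound 3 alter the same saturated chain carbon bound to a carbonyl carbon and a nitrogen on an aromatic ring, so they bear on this change, but their size cannot be read, and no measured step gives a direction for this assay. Compound 4 is therefore expected to sit near the limit as well, the step that the limit leaves unreadable from compound 3 to compound 4 being expected small. The estimate for compound 4 in this assay is 15000 nM, ranging from 4000 nM to 60000 nM.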

Compound 4, inhibition constant: > 10000 nM
Compound 4 ended at the assay's limit; the forecaster's own chance of this, stated with the estimate: 85%; the middle value lies beyond the limit too.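

Compound 4 gives only a limit in this assay, > 10000 nM. Its steps from compounds 1, 2 and 3 therefore cannot be read. The compounds shown leave open how these four rank in this assay, and whether any change to the shared core gives a measurable value.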